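This account rests on a few compounds, and the source may have more. Where it says the series, first, only, none or still open, it means among the compounds named here.

Compound 1 `O=C(CN1CCC(c2cccc[n+]2[O-])CC1)Nc1cccc(F)c1` gives 70% in a functional assay on HEK293 cells for agonist activity at D(4) dopamine receptor (Homo sapiens), read by FLIPR (a lower number here means a smaller maximal response, a higher number a larger maximal response), the highest of the three numbers seen so far; compound 2 `Cc1cccc(NC(=O)CN2CCC(c3ccc(O)cc3)CC2)c1` gives 60%, which lies within the scatter of compound 1, while compound 3 `CC(C)Oc1cccc(NC(=O)CN2CCC(c3cccc[n+]3[O-])CC2)c1` gives 48%. Within the data shown here, the single measured step on the group attached to the amide-type nitrogen is a number 22 percentage points lower from compound 1 to compound 3 (beyond the scatter). Compound 4 `O=C(CN1CCC(c2cccc[n+]2[O-])CC1)Nc1cccc(Cl)c1Cl` differs from compound 1 by 2,3-dichlorophenyl in place of 3-fluorophenyl on an amide-type nitrogen. Because a number 22 percentage points lower from compound 1 to compound 3 (beyond the scatter) shows that altering this group can lower the maximal response, a small decrease, or none beyond the scatter, is expected for compound 4. Compound 4 is therefore expected to give 62%, with a range of 45% to 78%. That expected step is a number 8 percentage points lower from compound 1 to compound 4 (within the scatter).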

Compound 4, largest response reached (reported as efficacy), in percent of the reference or control that the assay uses: 66%
The estimate for compound 4 lay 4 percentage points below the measured number, within the range that was stated.
By their numbers in this assay, from the lowest: compound 3; then compounds 2, 4 and 1 (each within the scatter of the next).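

In this assay, 2,3-dichlorophenyl in place of 3-fluorophenyl on the amide-type nitrogen gives a number 4 percentage points lower from compound 1 to compound 4 (within the scatter), so a change at this group need not lower the maximal response beyond the scatter. The earlier step at the same group, a number 22 percentage points lower from compound 1 to compound 3 (beyond the scatter), showed only a loss. Nothing available here explains why the two changes differ. On these data alone, it remains open whether an aromatic ring bearing an amine or a carboxylic acid would keep the response at this place, and whether a single chlorine would behave like the two in compound 4.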